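Swapping Methoxycarbonyl for Benzyl on a Saturated Ring Carbon

The source may report more compounds than this note shows. Statements on the series, on what has been measured and on what is new or still open speak of the compounds shown alone.

Of the compounds shown here, three sharing one core have been tested in a functional assay on FaDu cells (Homo sapiens) for inhibition, read by sulforhodamine B assay; on this read-out higher numbers stand for weaker inhibition and lower numbers for stronger inhibition. Compound 1, `COC(=O)CC/C(C)=C/Cc1c(OC)c(C)c2c(c1OCC#CCN1CCN(c3ccc(C)cc3)CC1)C(=O)OC2`, gives in this assay only the limit > 50000 nM, a limit of the assay and not a number. Compound 2, `COC(=O)CC/C(C)=C/Cc1c(OC)c(C)c2c(c1OCC#CCN1CCCc3ccccc31)C(=O)OC2`, likewise gives only the limit > 50000 nM. Compound 3, `COC(=O)CC/C(C)=C/Cc1c(OC)c(C)c2c(c1OCC#CCN1CCC(C(=O)OC)CC1)C(=O)OC2`, which carries 4-(methoxycarbonyl)piperidin-1-yl in place of 1,2,3,4-tetrahydroquinolin-1-yl on a saturated chain carbon bound to a triple-bonded carbon, also gives only the limit > 50000 nM. The step that the two limits leave unreadable from compound 2 to compound 3 therefore cannot be read, and compound 3 stands together with the other two at the limit of > 50000 nM in this assay, at which 3 of the 3 values shown sit.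

Compound 4, `COC(=O)CC/C(C)=C/Cc1c(OC)c(C)c2c(c1OCC#CCN1CCC(Cc3ccccc3)CC1)C(=O)OC2`, differs from compound 3 in one place: benzyl in place of methoxycarbonyl on a saturated ring carbon. For the measured compounds named here, no measured step bears on this change: every step among the three measured compounds begins and ends at a limit, so none shows how far any exchange of the group on this ring moves inhibition. No direction beyond the scatter can be expected from the numbers shown. On that basis the step of a number no higher from compound 3 to compound 4 (the limit leaves the size open) is estimated to be essentially flat. Compound 4 is expected to give 50000 nM, in a range from 5000 nM to 200000 nM, with a sizable chance that only a limit is again reported.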

Compound 4, half-maximal inhibitory concentration: > 50000 nM
Compound 4 was reported as a limit; the forecaster's own chance of this, stated with the estimate: 75%; the middle value lies on the limit itself.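

Compound 3 and compound 4 each give only a limit in this assay, so the exchange of methoxycarbonyl for benzyl yields no readable step, and the same holds across the whole set: the limit of > 50000 nM in this assay, at which 4 of the 4 values shown sit. The compounds shown leave open how strongly any of them inhibits, and whether any group on this ring changes that inhibition at all.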